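The source may hold more compounds than are shown below. What is called first, only, known or untested is meant among the compounds shown, and "the series" means these compounds.

In an ADME assay on LLC-PK1 cells (Sus scrofa) for permeability (on this read-out higher numbers stand for higher permeability and lower numbers for lower permeability), three compounds built on a shared core have been measured. Compound 1 (`C[C@]1(c2cc(NC(=O)c3ccc(Cl)cn3)cc(F)c2F)N=C(N)S[C@H]2C[C@H]21`) gives 13 10^-6 cm/s, compound 2 (`C[C@]1(c2cc(NC(=O)c3ccc(Cl)cn3)cc(F)c2F)N=C(N)S[C@@]2(C(N)=O)C[C@H]21`) gives 38 10^-6 cm/s and compound 3 (`CNC(=O)[C@]12C[C@H]1[C@@](C)(c1cc(NC(=O)c3ccc(Cl)cn3)cc(F)c1F)N=C(N)S2`) gives 29 10^-6 cm/s. Compound 3 thus sits within the scatter of compound 2, and its number is higher than that of compound 1. Compound 4 (`C[C@]1(c2cc(NC(=O)c3ccc(Cl)cn3)cc(F)c2F)N=C(N)S[C@@]2(C#N)C[C@H]21`) carries cyano in place of methylcarbamoyl on a saturated ring carbon. Within the data shown here, the only measured step that bears on this change is a 1.3-fold lower number from compound 2 to compound 3 (0.12 log units; within the scatter), a small one within the scatter. Among the measured compounds shown here, it alters the amide nitrogen of the same substituent, and no measured compound carries cyano, so its guidance is indirect. For the measured compounds named here, with only this step to go on, no step beyond the scatter is expected in this assay. The estimated step is a 1.0-fold higher number from compound 3 to compound 4 (0.01 log units; within the scatter), which would leave the number within the scatter. For compound 4, the expected value is 30 10^-6 cm/s, with an estimated range from 15 10^-6 cm/s to 55 10^-6 cm/s.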

Compound 4, apparent permeability: 39 10^-6 cm/s
For compound 4 the middle estimate is 1.3-fold (0.11 log units) below the measured one; measured number inside the range.
By their numbers in this assay, from the lowest: compound 1; then compounds 3, 2 and 4 (each within the scatter of the next).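

In this assay, replacing the amide with a nitrile on this saturated ring carbon leaves only small steps: cyano in place of methylcarbamoyl gives a 1.3-fold higher number from compound 3 to compound 4 (0.13 log units; within the scatter) and cyano in place of carbamoyl gives a 1.0-fold higher number from compound 2 to compound 4 (0.01 log units; within the scatter) on the same shared core. The earlier step altered only the amide nitrogen of this substituent, whereas here both the carbonyl and the amide hydrogen are absent, and compound 2, compound 3 and compound 4 still lie within the scatter of one another. Nothing shown accounts for this result.

On these data alone, whether the numbers stay this close with an amine, a carboxylic acid or a longer chain on the same carbon remains open. Also open, as far as these compounds go, is whether cyano gives the same picture when other parts of the shared core are changed.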